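Series notes: alkyne to alkene chain at the sulfonamide aryl

A few compounds are considered here, and "the series" means these few. Any claim that something is new, unique, unknown or untested is made for them only; others in the source may bear on it.

Two compounds of the shared core have numbers in a functional assay on A-375 cells (Homo sapiens) for antiproliferative activity, read by trypan blue exclusion, with a stated time of 48 h, tested at 1 uM; a lower number here means a stronger effect, a higher number a weaker effect of the compound at the concentration tested. Compound 1 `CC(=O)Nc1nc(-c2cccc(NS(=O)(=O)c3ccc(C#CC4CCCCC4)cc3)c2)cs1` gives 52.3%. For the measured compounds named here, compound 2 `CC(=O)Nc1nc(-c2cccc(NS(=O)(=O)c3ccc(C#CCCc4ccccc4)cc3)c2)cs1` gives 11.5%, the lowest of the two numbers; the only measured step, a number 40.8 percentage points lower from compound 1 to compound 2 (beyond the scatter), is large and beyond the scatter.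

Compound 3 `CCCCCC/C=C\c1ccc(S(=O)(=O)Nc2cccc(-c3csc(NC(C)=O)n3)c2)cc1` differs from compound 2 by a group of 8 heavy atoms (8 carbon; no ring) in place of a group of 10 heavy atoms (10 carbon; one six-membered aromatic ring of carbon only), on an aromatic carbon, on an aromatic carbon para to a large group. Going by the values given here, the one measured step concerns a swap of the group on the triple-bonded carbon while the triple bond itself stays, so it does not bear on this change, in which the triple bond leaves and a double bond outside aromatic rings enters with a chain of no ring. Among the compounds with values here, no step therefore sets a direction; as compound 2 already stands low, the expected step of a number 18.5 percentage points higher from compound 2 to compound 3 (beyond the scatter) is upward rather than downward, but with wide uncertainty. For compound 3 the estimate is 30%, within 8% to 60%.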

Compound 3, a percentage reported as activity, at one concentration (the size of the read-out at that concentration, not a potency): 48.8%
Beside the measured number, compound 3's estimate is 18.8 percentage points below it; the measured number falls inside the stated range.
By their numbers in this assay, from the lowest: compound 2; then compounds 3 and 1 (each within the scatter of the next).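

In this assay the swap of the 4-phenylbut-1-yn-1-yl group for the ring-free chain with one double bond gives a number 37.3 percentage points higher from compound 2 to compound 3 (beyond the scatter) and so shows that this para position does not tolerate the change without a large loss of effect at the concentration tested. The same chain set against the cyclohexyl-capped alkyne gives a number 3.5 percentage points lower from compound 1 to compound 3 (within the scatter) and leaves compound 1 and compound 3 level, with compound 2 alone standing apart. Nothing available accounts for these steps.

Since the aromatic ring and the triple bond leave together from compound 2 to compound 3, the compounds shown cannot assign the loss to either one. A 4-phenylbut-1-en-1-yl group, which keeps the terminal phenyl on a double bond, would separate the two, and a terminal amine on the chain remains an open question.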